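The source may report more compounds than this note shows. Statements on the series, on what has been measured and on what is new or still open speak of the compounds shown alone.

Measured so far in an assay on isolated protein for binding affinity to adenosine receptor A1 (Bos taurus); a lower number here means a stronger inhibitor, a higher number a weaker inhibitor:
Compound 1 `c1ccc(Cn2nnc3c(NC4CCCC4)nc(-c4ccccc4)nc32)cc1` gives 11000000 nM.
Compound 2 `COc1ccc(C(=O)Nc2nc(-c3ccccc3)nc3c2nnn3Cc2ccccc2Cl)cc1` gives 20000000 nM.
Compound 3 `Clc1ccccc1Cn1nnc2c(NC3CC3)nc(-c3ccccc3)nc21` gives 11000000 nM.

Compound 3 stands level with compound 1 at the digits reported, the two together the lowest of the three numbers; the only measured step among these compounds, a 1.8-fold lower number from compound 2 to compound 3 (0.26 log units; within the scatter), lies within the scatter, so all three values sit close together. Compound 4 `Clc1ccccc1Cn1nnc2c(NC3CCCC3)nc(-c3ccccc3)nc21` differs from compound 3 in one place: cyclopentyl in place of cyclopropyl on a nitrogen on an aromatic ring. Among the compounds with values here, the one measured step at this nitrogen on an aromatic ring, a 1.8-fold lower number from compound 2 to compound 3 (0.26 log units; within the scatter), exchanged a far larger group and still did not move the number beyond the scatter. Within the data shown here, compound 1 also carries cyclopentyl on that nitrogen, but it differs from compound 3 in a second place as well, so no single step links it to compound 3 or compound 4; its value and that of compound 3 simply agree at the digits reported. On this basis compound 4 is expected to show no change at the digits printed from compound 3 to compound 4 (within the scatter), that is, nothing beyond the scatter in this assay. The estimate for compound 4 is 11000000 nM, with a range from 5000000 nM to 25000000 nM.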

Compound 4, inhibition constant: 9000000 nM
The estimate for compound 4 lay 1.2-fold (0.09 log units) above the measured number, within the range that was stated.
By their numbers in this assay, from the lowest: compounds 4, 1, 3 and 2 (each within the scatter of the next, the first and the last beyond it).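

In this assay, cyclopentyl in place of cyclopropyl on the nitrogen gives a 1.2-fold lower number from compound 3 to compound 4 (0.09 log units; within the scatter) and thus extends the earlier picture to a change between two carbon rings. Chloro in place of hydrogen on an aromatic carbon gives a 1.2-fold lower number from compound 1 to compound 4 (0.09 log units; within the scatter) and is the first single step read at a place other than that nitrogen; it also stays within the scatter. Cyclopentyl in place of (4-methoxyphenyl)carbonyl gives a 2.2-fold lower number from compound 2 to compound 4 (0.35 log units; beyond the scatter) and, though modest, is the only step here that passes the scatter.

From the compounds shown here alone, whether an amine or a carboxylic acid on that aromatic carbon, or a longer chain on the nitrogen, would move the number further remains open. No measurement shown here speaks to why these numbers lie so close together.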